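The source may report more compounds than this note shows. Statements on the series, on what has been measured and on what is new or still open speak of the compounds shown alone.

Measured so far in a functional assay on NCI-H322M cells (Homo sapiens) for inhibition, read by sulforhodamine B assay, with a stated time of 48 h; a lower number here means a stronger inhibitor of growth, a higher number a weaker inhibitor of growth:
compound 1 `COc1cc(-c2nn(-c3cccc(NC(=O)Nc4ccc(Cl)c(Cl)c4)c3)cc2-c2ccncc2)ccc1Cl`: 1690 nM
compound 2 `COc1cc(-c2nn(-c3cccc(NC(=O)Nc4cccc(C(F)(F)F)c4)c3)cc2-c2ccncc2)ccc1Cl`: 1210 nM

Within the data shown here, compound 2 holds the lower of the two numbers, but compound 1 lies within the scatter of it; the only measured step, a 1.4-fold lower number from compound 1 to compound 2 (0.15 log units; within the scatter), exchanges the aryl on the amide-type nitrogen and stays within the scatter. Compound 3 `COc1cc(-c2nn(-c3cccc(NC(=O)c4ccc(Cl)c(C(F)(F)F)c4)c3)cc2-c2ccncc2)ccc1Cl` differs from compound 2 by 4-chloro-3-(trifluoromethyl)phenyl in place of (3-(trifluoromethyl)phenyl)amino on a carbonyl carbon. Among the measured compounds shown here, no measured step covers a change at the carbonyl carbon itself. For the measured compounds named here, since the one available step is within the scatter, no step beyond the scatter is expected for compound 3 in this assay, a 1.1-fold higher number from compound 2 to compound 3 (0.03 log units; within the scatter). Compound 3 is therefore estimated at 1300 nM, in the range 450 nM to 4000 nM.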

Compound 3, concentration for 50% growth inhibition: 12800 nM
Compound 3: middle estimate off by 9.8-fold (0.99 log units), on the low side; the whole stated range lies below it.
By their numbers in this assay, from the lowest: compounds 2 and 1 (each within the scatter of the next); then compound 3.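

In this assay, the change at the carbonyl carbon gives an 11-fold higher number from compound 2 to compound 3 (1.02 log units; beyond the scatter), and the same aryl in place of (3,4-dichlorophenyl)amino gives a 7.6-fold higher number from compound 1 to compound 3 (0.88 log units; beyond the scatter). This position therefore responds beyond the scatter, whereas exchanging the aryl while keeping the amino nitrogen did not. Nothing available explains the loss.

The step to compound 3 removes the amino nitrogen with its hydrogen-bond donor and also changes the aryl, so the two contributions cannot be separated. A (4-chloro-3-(trifluoromethyl)phenyl)amino group on the same carbonyl carbon would separate them.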